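Swapping dimethylamino for trifluoromethoxy on compound 3

The compounds below may be only part of what the source reports. "The series", "measured", "known", "first", "only" and "open" are said of these compounds alone.

Of the compounds shown here, three sharing one core have so far been tested in an ADME assay on Raji cells (Homo sapiens) for cytotoxicity, with a stated time of 72 h; a lower number here means that less compound is needed, a higher number that more compound is needed for the effect. For the measured compounds named here, compound 1 (`Cc1cc(NC(=O)Nc2ccc(Cl)c(Cl)c2)c2ccccc2n1`) gives 10000 nM, the only true number among them. Compound 2 (`Cc1cc(NC(=O)Nc2ccccc2C(C)(C)C)c2ccccc2n1`) gives > 25000 nM, which is a limit of the assay and not a number. Compound 3 (`Cc1cc(NC(=O)Nc2ccc(N(C)C)cc2)c2ccccc2n1`) gives > 25000 nM, which is also a limit. From the compounds shown here alone, compound 3 therefore stands at the limit of > 25000 nM in this assay, at which 2 of the 3 values shown sit, and its true value remains unknown.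

Compound 4 (`Cc1cc(NC(=O)Nc2ccc(OC(F)(F)F)cc2)c2ccccc2n1`) keeps the shared core and has trifluoromethoxy in place of dimethylamino on an aromatic carbon of compound 3: trifluoromethoxy in place of dimethylamino on an aromatic carbon. Going by the values given here, no two measured compounds differ in just one place, so this change has no direct precedent here. The closest guide is compound 1 at 10000 nM, which, like compound 4, has no dimethylamino group. Compound 2 also lacks that group and still gives > 25000 nM, a limit, so the guide is weak.

In this assay, a modest move toward a lower number is therefore expected. The estimated step is an at least 1.7-fold lower number from compound 3 to compound 4 (0.25 log units; that floor lies within the scatter), and it starts from a limit rather than a true number. For compound 4 the expected value is 14000 nM, with an estimated range from 6000 nM to 25000 nM.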

Compound 4, half-maximal effective concentration: 10000 nM
Beside the measured number, compound 4's estimate is 1.4-fold (0.15 log units) above it, within the range that was stated.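

For the compounds shown here, the swap of dimethylamino for trifluoromethoxy gives an at least 2.5-fold lower number from compound 3 to compound 4 (0.39 log units; beyond the scatter) in this assay and is the first change here that can be read on its own, as compounds 3 and 4 differ in one place only. This shows that the group on this aromatic carbon, para to a large group, can shift the read-out even though dimethylamino and trifluoromethoxy have the same counts of hydrogen-bond donors and acceptors and neither carries a net charge. The step has only a lower bound, because the value for compound 3 is a limit and not a number: the limit of > 25000 nM in this assay, at which 2 of the 4 values shown sit.

From the compounds shown here alone, with a single replacement read at this place, it remains open whether the step follows from losing dimethylamino or from gaining trifluoromethoxy, and a simple methoxy group, a primary amine or a carboxylic acid at the same carbon would help to separate the two. Going by these compounds alone, it also remains open whether the same swap would give a step of similar size if the rest of the molecule were different, since this pair is the only example of it.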